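Bromo at a new ring position on compound 1

This account rests on a few compounds, and the source may have more. Where it says the series, first, only, none or still open, it means among the compounds named here.

Measured compounds in a functional assay on HBL-100 cells (Homo sapiens) for inhibition, read by sulforhodamine B assay, with a stated time of 48 h; on this read-out lower numbers stand for stronger inhibition of growth and higher numbers for weaker inhibition of growth:
Compound 1 `COC(=O)[C@@]1(C)CCC=C2[C@@H]1CC[C@@H](C)[C@]2(C)Cc1c[nH]c2ccccc12` gives 4500 nM.
Compound 2 `COC(=O)[C@@]1(C)CCC=C2[C@@H]1CC[C@@H](C)[C@]2(C)Cc1c[nH]c2ccc(Br)cc12` gives 16000 nM.
Compound 3 `COC(=O)[C@@]1(C)CCC=C2[C@@H]1CC[C@@H](C)[C@]2(C)Cc1c[nH]c2ccc(C(F)(F)F)cc12` gives 15000 nM.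

Compound 1 stands lowest of the three numbers in this assay; its nearest neighbour is compound 3, seen in a 3.3-fold higher number from compound 1 to compound 3 (0.52 log units; beyond the scatter), and compound 2 lies furthest, seen in a 3.6-fold higher number from compound 1 to compound 2 (0.55 log units; beyond the scatter). Compound 4 `COC(=O)[C@@]1(C)CCC=C2[C@@H]1CC[C@@H](C)[C@]2(C)Cc1c[nH]c2c(Br)cccc12` carries the change (bromo in place of hydrogen on an aromatic carbon). Within the data shown here, no measured step places a group at this position; the two steps that bear on it both put a substituent on the same ring and both raised the number modestly, a 3.6-fold higher number from compound 1 to compound 2 (0.55 log units; beyond the scatter) and a 3.3-fold higher number from compound 1 to compound 3 (0.52 log units; beyond the scatter). On that basis compound 4 is expected to show a modest rise in this assay, estimated as 9000 nM within 3000 nM to 27000 nM, a step of a 2.0-fold higher number from compound 1 to compound 4 (0.30 log units; within the scatter).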

Compound 4, concentration for 50% growth inhibition: 18000 nM
Estimate against measurement, compound 4: 2.0-fold (0.30 log units) below; the measured number falls inside the stated range.
By their numbers in this assay, from the lowest: compound 1; then compounds 3, 2 and 4 (each within the scatter of the next).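

In this assay, bromo on this aromatic carbon, ortho to a fused ring and meta to a fused ring, gives a 4.0-fold higher number from compound 1 to compound 4 (0.60 log units; beyond the scatter) and so shows that the number also rises at a second ring position. Compounds 2 and 4 stand within the scatter of each other, so these two bromo placements are not told apart. Nothing available accounts for this rise. As far as these compounds go, whether an amine or a carboxylic acid on this same carbon would also raise the number remains open.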